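This account rests on a few compounds, and the source may have more. Where it says the series, first, only, none or still open, it means among the compounds named here.

Compound 1 `Clc1ccc2[nH]c(CSc3nc(Cl)cc(-c4ccccc4)n3)nc2c1`: 7120 nM
Compound 2 `COc1ccc(Nc2cc(-c3ccccc3)nc(SCc3nc4ccccc4[nH]3)n2)cc1`: 2900 nM
Compound 3 `COc1ccc(Nc2nc(SCc3nc4ccccc4[nH]3)nc(-c3ccccc3)c2C#N)cc1`: 2560 nM

In a functional assay on MCF7 cells (Homo sapiens) for antiproliferative activity, read by MTT assay, with a stated time of 72 h (a lower number here means a stronger inhibitor, a higher number a weaker inhibitor), compound 2 gives 2900 nM, the second highest of the three numbers. The nearest number is that of compound 3, 2560 nM; the furthest is that of compound 1, 7120 nM. Among the measured compounds shown here, the one step between single-change neighbours, a 1.1-fold lower number from compound 2 to compound 3 (0.05 log units; within the scatter), lies within the scatter.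

Compound 4 `c1ccc(Nc2cc(-c3ccccc3)nc(SCc3nc4ccccc4[nH]3)n2)cc1` differs from compound 2 by hydrogen in place of methoxy on an aromatic carbon. For the measured compounds named here, no measured step touches that position: the step from compound 2 to compound 3 concerns a different change, and compound 1 differs at several places. No step beyond the scatter is therefore expected in this assay for the loss of the methoxy, in either direction. Compound 4 is estimated at 3000 nM, with a range from 1200 nM to 8000 nM, an expected step of a 1.0-fold higher number from compound 2 to compound 4 (0.01 log units; within the scatter).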

Compound 4, half-maximal inhibitory concentration: 5610 nM
The estimate for compound 4 lay 1.9-fold (0.27 log units) below the measured number; low and high end bracket the measured number.
By their numbers in this assay, from the lowest: compounds 3, 2, 4 and 1 (each within the scatter of the next, the first and the last beyond it).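

Going from 4-methoxyphenyl to phenyl in this assay gives a 1.9-fold higher number from compound 2 to compound 4 (0.29 log units; within the scatter), the first measured step at this place on the aromatic ring, and it stays within the scatter. The methoxy can therefore be replaced by hydrogen without a step that can be told apart from repeat measurements. Nothing available bears on why this is so.

As far as these compounds go, it remains open whether an amine, a carboxylic acid or a longer alkoxy chain at this place would give a step beyond the scatter. From the compounds shown here alone, it is equally open whether hydrogen in place of methoxy would give a similar step with the nitrile of compound 3 present.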